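The source may hold more compounds than are shown below. What is called first, only, known or untested is meant among the compounds shown, and "the series" means these compounds.

Working notes on the series in a functional assay on T47D cells (Homo sapiens) for inhibition, read by sulforhodamine B assay, with a stated time of 48 h; on this read-out lower numbers stand for stronger inhibition of growth and higher numbers for weaker inhibition of growth.

Compound 1, `COC(=O)[C@@]1(C)CC[C@@H]2C3=C1CC[C@@H](C)[C@]3(C)C[C@@H]1c3cc(C)ccc3N[C@H]21`, gives 23000 nM in this assay. Compound 2, `COC(=O)[C@@]1(C)CC[C@@H]2C3=C1CC[C@@H](C)[C@]3(C)C[C@@H]1c3cc(Br)ccc3N[C@H]21`, carries one change against compound 1, (bromo in place of methyl on an aromatic carbon), and in this assay compound 2 gives 31000 nM. The step is a 1.3-fold higher number from compound 1 to compound 2 (0.13 log units; within the scatter).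

Compound 3, `COC(=O)[C@@]1(C)CC[C@@H]2C3=C1CC[C@@H](C)[C@]3(C)C[C@@H]1c3cccc(C)c3N[C@H]21`, has the same atoms as compound 1 joined differently; the difference between the two cores is not broken down here. In this assay compound 3 gives 29000 nM. Its number and those of compound 1 and compound 2 all lie within the scatter of one another, so no order among the three can be read from them.

Compound 4, `COC(=O)[C@@]1(C)CC[C@@H]2C3=C1CC[C@@H](C)[C@]3(C)C[C@@H]1c3cccc(Br)c3N[C@H]21`, is not yet measured. Against compound 3 it carries bromo in place of methyl on an aromatic carbon. For the measured compounds named here, this is the same kind of change as the one from compound 1 to compound 2, but not the same: in the earlier pair the site is meta to a fused ring and para to a fused ring, whereas in compound 4 the site is ortho to a fused ring and meta to a fused ring.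

Going by the values given here, with only one earlier example of this kind of change, the expectation for compound 4 rests on compound 3 with 29000 nM and on the size of a 1.3-fold higher number from compound 1 to compound 2 (0.13 log units; within the scatter). The step from compound 3 to compound 4 is expected to be a 1.2-fold higher number from compound 3 to compound 4 (0.09 log units; within the scatter), within the scatter. Compound 4 is therefore estimated at 36000 nM, with a range from 18000 nM to 75000 nM.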

Compound 4, concentration for 50% growth inhibition: 37000 nM
Compound 4: the middle estimate sits 1.0-fold (0.01 log units) below what was measured; measured number inside the range.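

In this assay, bromo in place of methyl on an aromatic carbon gives a 1.3-fold higher number from compound 3 to compound 4 (0.11 log units; within the scatter), and this step can be set beside the earlier one on the other core: the same change on two cores in this assay, a 1.3-fold higher number (0.13 log units; within the scatter) from compound 1 to compound 2 and a 1.3-fold higher number (0.11 log units; within the scatter) from compound 3 to compound 4, 1.1-fold (0.02 log units) apart, within the scatter of two such steps

Within these two pairs, then, the change carries from one core to the other with no difference that can be read, and the step measured on the first core would have served as a fair guide to the step on the second. This does not show that bromo and methyl differ in this series, as each step on its own lies within the scatter, and it does not show that the two sites are equivalent in general, as two small steps give no test of whether a larger step would transfer. Nor can anything be said about a third core, or about any cause for the agreement.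

From the compounds shown here alone, whether an amine, a carboxylic acid or a longer chain on this aromatic carbon would give a step beyond the scatter in this assay remains open. Also open, going by these compounds, is whether the same agreement between cores would appear for such a group, or in any other assay.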